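Aryl amide change from compound 2 to compound 3

The source may hold more compounds than are shown below. What is called first, only, known or untested is meant among the compounds shown, and "the series" means these compounds.

In a functional assay on HOS cells (Homo sapiens) for inhibition, read by MTT assay, with a stated time of 72 h (a higher number here means a weaker inhibitor, a lower number a stronger inhibitor), compound 1 `O=C(CCC(=O)OCCCCCCSc1ccc([N+](=O)[O-])c2nonc12)Nc1ccccc1F` gives 2350 nM and compound 2 `COc1ccccc1NC(=O)CCC(=O)OCCCCCCSc1ccc([N+](=O)[O-])c2nonc12` gives 2850 nM. For the measured compounds named here, compound 2 therefore stands level with compound 1, the only other measured member of the series. Going by the values given here, the single measured step, a 1.2-fold higher number from compound 1 to compound 2 (0.08 log units; within the scatter), is methoxy in place of fluoro on an aromatic carbon and lies within the scatter.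

The next compound, compound 3 `O=C(CCC(=O)OCCCCCCSc1ccc([N+](=O)[O-])c2nonc12)Nc1cccc(Cl)c1`, has 3-chlorophenyl in place of 2-methoxyphenyl on an amide-type nitrogen. The same measured step is the only one that bears on this change, as it also alters the aryl group on that nitrogen. Among the compounds with values here, the evidence is thin and indirect, since no measured compound carries a 3-chlorophenyl group. Given only a 1.2-fold higher number from compound 1 to compound 2 (0.08 log units; within the scatter), no step beyond the scatter is expected in this assay. The expected step is a 1.1-fold lower number from compound 2 to compound 3 (0.04 log units; within the scatter). Compound 3 is estimated at 2600 nM, with an expected range of 1200 nM to 5500 nM.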

Compound 3, half-maximal inhibitory concentration: 1920 nM
Compound 3: middle estimate off by 1.4-fold (0.13 log units), on the high side; the range from low to high includes it.
By their numbers in this assay, from the lowest: compounds 3, 1 and 2 (each within the scatter of the next).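

In this assay, replacing 2-methoxyphenyl with 3-chlorophenyl on the amide-type nitrogen gives a 1.5-fold lower number from compound 2 to compound 3 (0.17 log units; within the scatter) and replacing 2-fluorophenyl with the same group gives a 1.2-fold lower number from compound 1 to compound 3 (0.09 log units; within the scatter), so the three aryl amides stay within the scatter of one another. This position therefore shows no measurable response here to a change that exchanges the group's substituent and its ring position together, and that also removes the hydrogen-bond acceptor counted in 2-methoxyphenyl, which the fluoro-to-methoxy step alone did not test. No measurement on hand offers a reason for these closely grouped numbers.

Since both the substituent and its ring position differ in this step, 2-chlorophenyl and 3-methoxyphenyl on the same nitrogen would be needed to separate the two, and plain phenyl would give the reference point for all these aryl amides. Going by these compounds, whether this flat response persists further out remains open for a pyridine ring or a carboxylic acid on the aryl group, and for a longer chain joining the ester to the shared core.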